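The source may report more compounds than this note shows. Statements on the series, on what has been measured and on what is new or still open speak of the compounds shown alone.

Of the compounds shown here, two that share a core have been tested in an ADME assay on HepG2 cells (Homo sapiens) for cytotoxicity, read by luminescence, CellTiter-Glo and ATP content, with a stated time of 72 h; on this read-out higher numbers stand for an effect only at larger amounts of compound and lower numbers for an effect already at smaller amounts. Compound 1 `COc1ccc(Oc2ccc3c(NCCCNCc4cc(F)ccc4OC)ccnc3c2)cc1` gives 7000 nM in this assay, and compound 2 `CC(C)CCc1ccc2c(NCCCNCc3ccco3)ccnc2c1` gives 11200 nM. These two numbers lie within the scatter of each other, so compound 1 stands at the same level as compound 2 rather than apart from it, and nothing separates the two on the numbers shown.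

Compound 3 `COc1cccc(Oc2ccc3c(NCCCNCc4cc(F)ccc4OC)ccnc3c2)c1` has not yet been measured in this assay. It holds the same atoms as compound 1, joined differently: 3-methoxyphenyl in place of 4-methoxyphenyl on an oxygen on an aromatic ring. Among the compounds with values here, no pair of measured compounds differs by this kind of change alone, so there is no measured step to build on. With the same ring and the same methoxy group retained in compound 3, the expectation is that it will behave much like compound 1 in this assay. The step of no change at the digits printed from compound 1 to compound 3 (within the scatter) is expected to be none beyond the scatter. The estimate for compound 3 in this assay is 7000 nM, expected to fall between 3000 nM and 16000 nM.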

Compound 3, half-maximal effective concentration: 7100 nM
Compound 3: middle estimate off by 1.0-fold (0.01 log units), on the low side; the measured number falls inside the stated range.
By their numbers in this assay, from the lowest: compounds 1, 3 and 2 (each within the scatter of the next).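

In this assay the change to 3-methoxyphenyl in place of 4-methoxyphenyl, on an oxygen on an aromatic ring, gives a 1.0-fold higher number from compound 1 to compound 3 (0.01 log units; within the scatter) and so leaves the two placements of the methoxy group indistinguishable here. Compound 1 and compound 2 differ in more than one place, so they could not speak to any single group, whereas this pair holds the same atoms joined differently and isolates one change at one position. Nothing measured here explains why the two numbers stand so close together.

This single pair does not show whether the methoxy group itself matters at this position, which a plain phenyl ring, or a ring carrying an amine or a carboxylic acid in place of the methoxy group, would begin to test. It also leaves open whether the same change would read alike on a compound with a different side chain.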